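Side-chain amine replacement toward compound 4

A few compounds are considered here, and "the series" means these few. Any claim that something is new, unique, unknown or untested is made for them only; others in the source may bear on it.

Measured so far in a functional assay on MCF7 cells (Homo sapiens) for antiproliferative activity; a lower number here means a stronger inhibitor, a higher number a weaker inhibitor:
compound 1, `CC(=O)Oc1ccc(C(=O)Nc2cc3ccc(OCC4CCN(C)C4)c(C)c3oc2=O)cc1CC=C(C)C`: 1880 nM
compound 2, `CCNCCCOc1ccc2cc(NC(=O)c3ccc(O)c(CC=C(C)C)c3)c(=O)oc2c1C`: 980 nM
compound 3, `CC(C)=CCc1cc(C(=O)Nc2cc3ccc(OCCCNC(C)C)c(C)c3oc2=O)ccc1O`: 740 nM

Compound 3 holds the lowest of the three numbers. Its nearest neighbour is compound 2: the step of a 1.3-fold lower number from compound 2 to compound 3 (0.12 log units; within the scatter) lies within the scatter, so the two cannot be ordered. Compound 1, with 1880 nM, lies beyond the scatter from compound 3, but it also carries an acetate in place of the phenol and an amine inside a ring, so its gap is not a single step.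

Compound 4, `CC(C)=CCc1cc(C(=O)Nc2cc3ccc(OCCCN(C)c4ccccc4)c(C)c3oc2=O)ccc1O`, differs from compound 3 by methyl(phenyl)amino in place of isopropylamino on a saturated chain carbon, three bonds along the chain from an oxygen on an aromatic ring. Going by the values given here, the only measured step at the amine, from compound 2 to compound 3, was small, and no measured pair exchanges the hydrogen-bond donor on the nitrogen for an aromatic ring. The expectation is therefore a modest step toward a higher number, a 1.6-fold higher number from compound 3 to compound 4 (0.21 log units; within the scatter), with wide uncertainty. For compound 4 the estimate is 1200 nM, expected between 500 nM and 3000 nM.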

Compound 4, half-maximal inhibitory concentration: > 50000 nM
Compound 4: a limit, no number; the forecaster's own chance of this, stated with the estimate: 5%; middle value at least 41-fold (1.61 log units) away from the limit.
By their numbers in this assay, from the lowest: compounds 3, 2 and 1 (each within the scatter of the next, the first and the last beyond it). At a limit, above all of these: compound 4.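

In this assay, the exchange at the end of the chain gives an at least 67-fold higher number from compound 3 to compound 4 (1.82 log units; beyond the scatter), and from the ethylamino side it gives an at least 51-fold higher number from compound 2 to compound 4 (1.70 log units; beyond the scatter). Going by these compounds alone, both are large, whereas the only earlier step at this amine, a 1.3-fold lower number from compound 2 to compound 3 (0.12 log units; within the scatter), lies within the scatter. Compound 4 carries a limit and not a number: the limit of > 50000 nM in this assay, at which 1 of the 4 values shown sits. This position, on a saturated chain carbon three bonds along the chain from an oxygen on an aromatic ring, therefore does respond to the group it carries, which the swap between small alkylamino groups did not show.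

The change removes the hydrogen-bond donor and brings in a six-membered aromatic ring in one step, and the compounds shown do not separate the two. Open, as far as these compounds go, is whether dimethylamino, with no ring and no donor, or phenylamino, with both, falls with compound 3 or with compound 4.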